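This account rests on a few compounds, and the source may have more. Where it says the series, first, only, none or still open, it means among the compounds named here.

Compound 1 `Cn1c(-c2ccc(C#N)cc2)cnc1NC(=O)c1ncc[nH]1` and compound 2 `COc1ccc(-c2cnc(NC(=O)C3CCCCC3)n2C)cc1` share a core and were both tested in a toxicity assay on THP-1 cells (Homo sapiens) for inhibition; a higher number here means that more compound is tolerated, a lower number that less compound is tolerated. In this assay compound 1 gives only a limit of the assay, > 100000 nM. In this assay compound 2 likewise gives only a limit of the assay, > 100000 nM. Going by the values given here, compound 2 therefore stands at the limit of > 100000 nM in this assay, at which 2 of the 2 values shown sit; no number is known for it, and no step between two measured compounds can be read from these data.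

The unmeasured compound 3 `COc1ccc(-c2cnc(NC(=O)c3ccc(F)cc3)n2C)cc1` differs from compound 2 in one place: 4-fluorophenyl in place of cyclohexyl on a carbonyl carbon. With nothing but limits in hand for compound 1 and compound 2, the expectation for compound 3 rests on the limit of compound 2 alone, and the change is expected to bring no step beyond the scatter in either direction. In this assay compound 3 is expected to give about 120000 nM, with a range from 50000 nM to 300000 nM. This estimate means an expected step that the limit leaves unreadable from compound 2 to compound 3, lying within the scatter, so compound 3 is most likely to return once more as a limit rather than a number.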

Compound 3, half-maximal cytotoxic concentration: >= 50000 nM
Compound 3: a limit, no number; the forecaster's own chance of this, stated with the estimate: 75%; the middle value is on the limit's open side.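

In this assay compound 3 gives only a limit of the assay, >= 50000 nM. Compound 2 likewise gives only a limit, > 100000 nM. Going by these compounds alone, no step from compound 2 to compound 3 can be read. The compounds shown leave open the actual half-maximal cytotoxic concentration of each, and whether 4-fluorophenyl in place of cyclohexyl changes it at all.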